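Swapping an Oxopiperazine Ring and Plasma Half-Life

The source may hold more compounds than are shown below. What is called first, only, known or untested is meant among the compounds shown, and "the series" means these compounds.

The measurement followed here is an ADME assay on a cell-free system (plasma, Mus musculus) for metabolic stability, read by LC-MS, tested at 2 uM; on this read-out higher numbers stand for a longer-lived compound and lower numbers for a shorter-lived compound. In this assay, compound 1 `CC(C)CNC(=O)n1c(=O)oc2ccc(C3CCN(C)CC3)cc21` gives 0.5 h, and compound 2 `CN1CCN(c2ccc3c(c2)oc(=O)n3C(=O)NCCCCc2ccccc2)C(=O)C1` gives 0.333 h. These two numbers lie within the usual scatter of repeated measurements, so compound 2 stands level with compound 1 on the data so far. The two compounds also differ in more than one place, so they show nothing about any single structural change.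

Compound 3 `CN1CCN(c2ccc3c(c2)oc(=O)n3C(=O)NCCCCc2ccccc2)CC1=O` has not yet been measured. It has the same atoms as compound 2, joined differently: 4-methyl-3-oxopiperazin-1-yl in place of 4-methyl-2-oxopiperazin-1-yl on an aromatic carbon. The swap sits on an aromatic carbon of the shared core. Among the compounds with values here, no measured pair shows what a swap of this kind does, so the expectation rests on compound 2 and its 0.333 h. The estimated 1.1-fold higher number from compound 2 to compound 3 (0.02 log units; within the scatter) is expected to stay within the scatter, with no clear direction in this assay. For compound 3 the estimate is 0.35 h, with an expected range from 0.17 h to 0.75 h.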

Compound 3, half-life: 0.333 h
Beside the measured number, compound 3's estimate is 1.1-fold (0.02 log units) above it; the measured number falls inside the stated range.
By their numbers in this assay, from the lowest: compounds 2, 3 and 1 (each within the scatter of the next).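

Placing 4-methyl-3-oxopiperazin-1-yl in place of 4-methyl-2-oxopiperazin-1-yl on an aromatic carbon of the shared core gives, in this assay, no change at the digits printed from compound 2 to compound 3 (within the scatter). Within the data shown here, this is the first pair here that differs in one place only, so it offers the first direct reading of a single structural change, and at this position the two ring forms cannot be told apart in this read-out. Nothing measured here bears on why the two compounds read alike.

Among these compounds, this single pair covers only two closely related rings, which carry the same atoms joined differently, so it says nothing about a group of another kind on this aromatic carbon, such as an open-chain amine, a carboxylic acid or a morpholine ring. It also leaves open whether the same swap would read alike if the rest of the shared core were changed, since one pair on one background cannot establish a general pattern.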